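Methoxy for butylamino on a shared purine-like core

The source may report more compounds than this note shows. Statements on the series, on what has been measured and on what is new or still open speak of the compounds shown alone.

Measured compounds:
compound 1, `Nc1ncnc2c1nc(O)n2Cc1ccc(Cl)cc1`, 10 uM
compound 2, `CCCCNc1nc(N)c2nc(O)n(Cc3ccccc3)c2n1`, 1 uM
compound 3, `Nc1ncnc2c1nc(O)n2Cc1cccc2ccccc12`, 10 uM

Of the compounds shown here, three have been tested in a functional assay (spleen, spleen) for activation, with Mus musculus as the target; a higher number here means that more compound is needed for the effect, a lower number that less compound is needed. Compound 1 gives 10 uM, and compound 3, which carries a larger aromatic group on the ring nitrogen, gives 10 uM, the same number. Compound 2 stands lowest of the three with 1 uM; both other compounds sit beyond the scatter from it, so compound 2 needs the least compound for the effect. Compound 2 differs from the other two in more than one place, so no single structural step can be read from the measured set.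

Compound 4, `COc1nc(N)c2nc(O)n(Cc3ccccc3)c2n1`, has not yet been measured. It differs from compound 2 in one place: methoxy in place of butylamino on an aromatic carbon. The group that leaves is longer and carries a hydrogen-bond donor; the group that enters is short and carries only an acceptor. Among the compounds with values here, with no measured step of this kind to lean on, the author expects a modest rise in this assay, within or just beyond the scatter, for the step of a 3.0-fold higher number from compound 2 to compound 4 (0.48 log units; beyond the scatter). For compound 4 the estimate is 3 uM, in the range from 1 uM to 10 uM.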

Compound 4, minimum effective concentration: 0.1 uM
For compound 4 the middle estimate is 30-fold (1.48 log units) above the measured one, and the stated range ends above it.
By their numbers in this assay, from the lowest: compound 4; then compound 2; then compounds 1 and 3 (each within the scatter of the next).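

In this assay, within the data shown here, methoxy in place of butylamino on an aromatic carbon gives a 10-fold lower number from compound 2 to compound 4 (1.00 log units; beyond the scatter) and so provides the first comparison in the set that differs in one place. At this position, between two ring nitrogen atoms, the effect therefore does not depend on keeping the butylamino chain or its hydrogen-bond donor, since methoxy has no such donor and less compound is needed. Nothing available bears on why the number falls.

The compounds shown leave open whether butoxy, ethoxy or methylamino at this position would behave like methoxy or like butylamino, which would separate the effect of the linking atom from that of chain length. Nor can this step be carried over to compound 1 or compound 3, which differ from compound 2 in more than one place.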